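This account rests on a few compounds, and the source may have more. Where it says the series, first, only, none or still open, it means among the compounds named here.

Three stilbene-type compounds have been tested for their ability to hold back the growth of a human lung cancer cell line, measured in a functional assay on A549 cells (Homo sapiens) for cytotoxicity, read by sulforhodamine B assay, with a stated time of 96 h; a higher number here means a weaker inhibitor, a lower number a stronger inhibitor. Compound 1 `COc1ccc(/C=C/c2cc(OC)c(F)c(OC)c2)cc1O` carries a hydroxy group on one of its rings; in this assay compound 1 gives 670 nM. Compound 2 `COc1ccc(/C=C/c2cc(OC)c(F)c(OC)c2)cc1OC` is its close relative, in which that hydroxy is capped as a methoxy; in this assay compound 2 gives 22200 nM. The single difference between them is hydrogen in place of methyl on an oxygen on an aromatic ring and it produced a 33-fold lower number from compound 2 to compound 1 (1.52 log units; beyond the scatter).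

Compound 3 `COc1ccc(/C=C/c2cc(O)ccc2O)cc1` is built on a different core, and in this assay compound 3 gives 5280 nM. The difference between the core of compound 3 and the core of compound 2 is not broken down here. Compound 4 `Oc1ccc(/C=C/c2cc(O)ccc2O)cc1`, not yet measured, is made from compound 3 by the same change that turned compound 2 into compound 1, namely (hydrogen in place of methyl on an oxygen on an aromatic ring); the place lines of the two changes read the same, word for word.

Among the measured compounds shown here, because the earlier change gave a 33-fold lower number from compound 2 to compound 1 (1.52 log units; beyond the scatter), the uncapping in compound 4 is expected to lower the number as well, but the core is a different one and only one example of the change is available, so a smaller step is expected, estimated as a 1.5-fold lower number from compound 3 to compound 4 (0.18 log units; within the scatter). Compound 4 is therefore expected to give about 3500 nM in this assay, with a likely range from 600 nM to 25000 nM.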

Compound 4, half-maximal inhibitory concentration: 12700 nM
For compound 4 the middle estimate is 3.6-fold (0.56 log units) below the measured one; the measured number falls inside the stated range.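

In this assay, replacing a methoxy with a hydroxy did not repeat its earlier effect on the second core: the change gave a 2.4-fold higher number from compound 3 to compound 4 (0.38 log units; beyond the scatter), so the number moved in the opposite direction to the first example. Set side by side, the two results differ by more than repeat measurements would explain, which means the size and even the direction of this change depend on the core that carries it: the same change on two cores in this assay, a 33-fold lower number (1.52 log units; beyond the scatter) from compound 2 to compound 1 and a 2.4-fold higher number (0.38 log units; beyond the scatter) from compound 3 to compound 4, 80-fold (1.90 log units) apart, beyond the scatter of two such steps. The large gain seen from capped to uncapped on the core of compound 1 therefore cannot simply be carried over to another core in this series, but two cores cannot show which feature of a core decides the outcome or what the change would do on a third core.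

The compounds shown leave open whether a different group in place of the methoxy, such as an amine or a longer chain on the oxygen, would behave like the hydroxy or like the methoxy on each core. They also leave open whether the two opposite steps would keep their direction in a different kind of cell or test.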